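Replacing the 2-aminophenyl group of compound 3

The source may report more compounds than this note shows. Statements on the series, on what has been measured and on what is new or still open speak of the compounds shown alone.

- compound 1 `COC(=O)C1=C(C)N=C(C)/C(=C(\O)OC)C1c1cc(Cl)cc(Cl)c1`: 93.3 nM
- compound 2 `COC(=O)C1=C(C)N=C(C)/C(=C(\O)OC)C1c1ccccc1Cl`: 2.19 nM
- compound 3 `COC(=O)C1=C(C)N=C(C)/C(=C(\O)OC)C1c1ccccc1N`: 39800 nM

These values come from a functional assay (muscle tissue) with Cavia porcellus as the target; on this read-out higher numbers stand for an effect only at larger amounts of compound and lower numbers for an effect already at smaller amounts. Compound 3, at 39800 nM, has the highest number of the three. Compound 4 `COC(=O)C1=C(C)N=C(C)/C(=C(\O)OC)C1c1ccc(F)cc1` carries 4-fluorophenyl in place of 2-aminophenyl on a saturated ring carbon. Two large measured steps lead to the 2-aminophenyl group: a 430-fold higher number from compound 1 to compound 3 (2.63 log units; beyond the scatter) and an 18000-fold higher number from compound 2 to compound 3 (4.26 log units; beyond the scatter). The remaining step, a 43-fold lower number from compound 1 to compound 2 (1.63 log units; beyond the scatter), shows how far the other two values lie apart, and neither compound carries 4-fluorophenyl. A large change towards a lower number is therefore expected in this assay: a 130-fold lower number from compound 3 to compound 4 (2.12 log units; beyond the scatter). For compound 4 the estimated value is 300 nM, with an expected range of 30 nM to 3000 nM.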

Compound 4, half-maximal effective concentration: 129 nM
The estimate for compound 4 lay 2.3-fold (0.37 log units) above the measured number; the range from low to high includes it.
By their numbers in this assay, from the lowest: compound 2; then compounds 1 and 4 (each within the scatter of the next); then compound 3.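

Swapping 2-aminophenyl for 4-fluorophenyl brings a 310-fold lower number from compound 3 to compound 4 (2.49 log units; beyond the scatter) while swapping 2-chlorophenyl for it brings a 59-fold higher number from compound 2 to compound 4 (1.77 log units; beyond the scatter) so 4-fluorophenyl escapes the high number of compound 3 but does not reach the low number of compound 2. Against 3,5-dichlorophenyl it gives a 1.4-fold higher number from compound 1 to compound 4 (0.14 log units; within the scatter) so these two groups cannot be told apart here. No measurement shown explains these differences. Still open, going by these compounds, is whether 2-fluorophenyl or 4-chlorophenyl would lie nearer compound 2 or compound 4, which would separate the choice of halogen from its place on the phenyl ring.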